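The compounds below may be only part of what the source reports. "The series", "measured", "known", "first", "only" and "open" are said of these compounds alone.

The account starts from compound 2 `CSc1nc(NCc2ccc([Se]C)cc2)c2ccccc2n1`. In a functional assay on HT-29 cells (Homo sapiens) for cytotoxicity, read by MTT assay, with a stated time of 72 h (a higher number here means a weaker inhibitor of growth, a lower number a stronger inhibitor of growth), compound 2 gives > 100000 nM, which is a limit of the assay and not a number. Compound 1 `CCCCCSc1nc(NCc2ccc([Se]C)cc2)c2ccccc2n1` differs from compound 2 in one place. In this assay compound 1 gives > 100000 nM, again a limit. The step that the two limits leave unreadable from compound 1 to compound 2 therefore cannot be read, because both of its values sit at the limit of > 100000 nM in this assay, at which 2 of the 3 values shown sit. Compound 3 `[SeH]c1nc([SeH])c2ccccc2n1` shares only the core with the others, and in this assay compound 3 gives 45200 nM. Compound 4 `CSc1nc(NCc2ccccc2)c2ccccc2n1` is reached from compound 2 by a hydrogen atom in place of a group of 2 heavy atoms (1 carbon, 1 selenium; no ring), on an aromatic carbon. Among the measured compounds shown here, no measured step follows this change, and the one measured step is unreadable, so the size of the step to compound 4 rests on nothing but the limit at which compound 2 stands. Compound 4 is therefore expected to stay at or near that limit, with an estimate of 120000 nM and a range from 40000 nM to 300000 nM. This estimate means a step that the limit leaves unreadable from compound 2 to compound 4, expected to fall within the scatter.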

Compound 4, concentration for total growth inhibition: > 100000 nM
Compound 4 ended at the assay's limit (the forecaster's own chance of this, stated with the estimate: 75%); the middle value does not contradict the limit.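

In this assay compound 4 gives > 100000 nM, a limit of the assay and not a number. Among the compounds shown here, compound 2 also stands at a limit, so no step between compound 2 and compound 4 can be read. The compounds shown leave open whether the group of 2 heavy atoms on the aromatic carbon affects growth inhibition at all.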